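A few compounds are considered here, and "the series" means these few. Any claim that something is new, unique, unknown or untested is made for them only; others in the source may bear on it.

In a functional assay on MCF7 cells (Homo sapiens) for antiproliferative activity, read by MTT assay, with a stated time of 48 h (a lower number here means a stronger inhibitor, a higher number a weaker inhibitor), three compounds have been measured:

Compound 1 `N#CC1=C(N)Oc2c(c3nc4ccccc4nc3c3ccccc23)C12C(=O)N(Cc1cnnn1-c1cccc(Cl)c1)c1ccccc12` gives 43600 nM.
Compound 2 `COc1ccccc1-n1nncc1CN1C(=O)C2(C(C#N)=C(N)Oc3c2c2nc4ccccc4nc2c2ccccc32)c2ccccc21` gives only a limit, > 50000 nM.
Compound 3 `N#CC1=C(N)Oc2c(N)cc3nc4ccccc4nc3c2C12C(=O)N(Cc1cnnn1-c1cccc(Br)c1)c1ccccc12` gives only a limit, > 50000 nM.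

Compound 3 thus stands at the edge of what this assay reports, with no number of its own. Compound 4 `Cc1ccc(Cl)cc1-n1nncc1CN1C(=O)C2(C(C#N)=C(N)Oc3c(N)cc4nc5ccccc5nc4c32)c2ccccc21` differs from it in one place: 5-chloro-2-methylphenyl in place of 3-bromophenyl on an aromatic nitrogen. For the measured compounds named here, the only measured step that changes the group on this aromatic nitrogen is an at least 1.1-fold higher number from compound 1 to compound 2 (0.05 log units; that floor lies within the scatter), which is within the scatter and ends at a limit. The same picture is given by the limit of > 50000 nM in this assay, at which 2 of the 3 values shown sit, so the change from a 3-bromophenyl to a 5-chloro-2-methylphenyl at this position is expected to move the read-out little, if at all. The expected step that the limit leaves unreadable from compound 3 to compound 4 is therefore no change beyond the scatter, and a limit rather than a number is the likelier outcome. Compound 4 is estimated to give 60000 nM in this assay, with a range from 25000 nM to 150000 nM.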

Compound 4, half-maximal inhibitory concentration: 43500 nM
Compound 4: middle estimate off by 1.4-fold (0.14 log units), on the high side; measured number inside the range.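

On the core shared by compound 3 and compound 4, the aromatic nitrogen carrying 5-chloro-2-methylphenyl yields a number and not a limit: in this assay compound 4 gives 43500 nM. On these data alone, replacing 3-bromophenyl with this group gives an at least 1.1-fold lower number from compound 3 to compound 4 (0.06 log units; that floor lies within the scatter), so no change beyond the scatter can be claimed, and the true size of the step stays unknown. Compound 3 itself is only a limit, > 50000 nM, and such limits are common in this small set: the limit of > 50000 nM in this assay, at which 2 of the 4 values shown sit.

The compounds shown do not separate the contribution of the methyl from that of the chlorine in the new group. As far as these compounds go, it also stays open whether a pyridyl ring, a benzyl group or a chain ending in an amine on this aromatic nitrogen would move the read-out beyond the scatter.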